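Compound 1 and the step to its 3-hydroxyphenyl analogue

The source may hold more compounds than are shown below. What is called first, only, known or untested is meant among the compounds shown, and "the series" means these compounds.

Values so far in a functional assay on MDA-MB-231 cells (Homo sapiens) for antiproliferative activity, read by MTT assay, with a stated time of 48 h (on this read-out lower numbers stand for stronger inhibition of growth and higher numbers for weaker inhibition of growth), are:
- compound 1 `COC(=O)N1N=C(c2cccc(OC)c2)CC1c1cc(OC)c(OC)c(OC)c1` gives 350 nM
- compound 2 `CCCOC(=O)N1N=C(c2cccc(OC)c2)CC1c1cc(OC)c(OC)c(OC)c1` gives 12500 nM

Compound 1 holds the lower of the two numbers in this assay and serves as the reference here. Compound 3 `COC(=O)N1N=C(c2cccc(O)c2)CC1c1cc(OC)c(OC)c(OC)c1` has not yet been measured. Its difference from compound 1 (hydrogen in place of methyl on an oxygen on an aromatic ring) is hydrogen in place of methyl on an oxygen on an aromatic ring, that is, methoxy to hydroxy, or 3-methoxyphenyl to 3-hydroxyphenyl.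

Within the data shown here, only one measured step is available (a 36-fold higher number from compound 1 to compound 2 (1.55 log units; beyond the scatter)). It is large and beyond the scatter, but it lies at a different place from this change, so it bears on the new step only indirectly. Among the measured compounds shown here, it shows that a single change to compound 1 can move the number a long way, while no measured step covers the methoxy group itself. A moderate move to a higher number is therefore expected, with wide uncertainty, and the estimated step is a 2.0-fold higher number from compound 1 to compound 3 (0.30 log units; within the scatter) in this series. The expected value for compound 3 is 700 nM (expected range 180 nM to 3000 nM).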

Compound 3, concentration for 50% growth inhibition: 740 nM
Estimate against measurement, compound 3: 1.1-fold (0.02 log units) below; measured number inside the range.
By their numbers in this assay, from the lowest: compound 1; then compound 3; then compound 2.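

In this assay, the change from methoxy to hydroxy on the aromatic ring gives a modest step (a 2.1-fold higher number from compound 1 to compound 3 (0.33 log units; beyond the scatter)), the only measured step at this place among the compounds shown. The methyl on this oxygen therefore matters to the read-out, since its replacement by hydrogen lies just beyond the usual scatter, yet the step is much smaller than the one at the other measured place (a 36-fold higher number from compound 1 to compound 2 (1.55 log units; beyond the scatter)), so compound 3 keeps much of the growth inhibition seen with compound 1. No supporting data shown here accounts for the size or direction of this step.

The compounds shown leave open how an amine, a carboxylic acid or a longer chain on this oxygen would read at the same place on the aromatic ring. From the compounds shown here alone, it also remains open whether the change from 3-methoxyphenyl to 3-hydroxyphenyl would give a step of similar size in the setting of compound 2, since the two measured steps have so far been read only from compound 1.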